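A few compounds are considered here, and "the series" means these few. Any claim that something is new, unique, unknown or untested is made for them only; others in the source may bear on it.

Of the compounds shown here, two have been measured so far. Compound 1 `CN(C)c1nc(NCc2ccc(C(=O)N3CCC(C(=O)NCc4ccc(F)cc4)CC3)cc2)c2ccccc2n1` and compound 2 `C=CCNc1nc(NCc2ccc(C(=O)NC3CCN(C(=O)c4ccc(F)cc4)CC3)cc2)c2cc(C)ccc2n1` share a core and differ at several points. In a functional assay on HCT-116 cells (Homo sapiens) for inhibition, read by luminescence and resazurin assay, with a stated time of 3 days (on this read-out lower numbers stand for stronger inhibition and higher numbers for weaker inhibition), compound 1 gives 5700 nM, the lowest of the two numbers, while compound 2 gives 6900 nM; the two numbers are within the scatter of each other, so nothing can be said about which of the two is the stronger inhibitor.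

Compound 3 `Cc1ccc2nc(N(C)C)nc(NCc3ccc(C(=O)N4CCC(C(=O)NCc5ccc(F)cc5)CC4)cc3)c2c1` is not yet measured. It differs from compound 1 in one place: methyl in place of hydrogen on an aromatic carbon. Within the data shown here, no measured pair showing exactly this change exists among the two compounds, so the size of the step is uncertain. Since the change adds a single carbon with no donor or acceptor, the step from compound 1 to compound 3 is expected to stay within the scatter, a 1.1-fold lower number from compound 1 to compound 3 (0.06 log units; within the scatter). Compound 3 is therefore estimated to give 5000 nM in this assay, within a range from 2000 nM to 12000 nM.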

Compound 3, half-maximal inhibitory concentration: 5600 nM
Estimate against measurement, compound 3: 1.1-fold (0.05 log units) below; the range from low to high includes it.
By their numbers in this assay, from the lowest: compounds 3, 1 and 2 (each within the scatter of the next).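

Among these compounds, this is the first pair of compounds that differ in one place, and in this assay methyl in place of hydrogen on this aromatic carbon gives a 1.0-fold lower number from compound 1 to compound 3 (0.01 log units; within the scatter), so the change can now be read directly rather than estimated. At this position of the core of compound 1, then, one added methyl leaves the number where it was, as far as this read-out can tell. Nothing available explains this result.

The compounds shown leave open whether this position would accept something other than methyl, such as a methoxy group, a chlorine atom or a longer chain like ethyl. They also leave open whether methyl in place of hydrogen on the other aromatic carbons of the core would give the same result.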